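The compounds below may be only part of what the source reports. "The series", "measured", "known", "first", "only" and "open" are said of these compounds alone.

Measured compounds:
compound 1 `COc1ccc(-n2ccc(=O)c(C(=O)Nc3ccc(Oc4ccnc5[nH]ccc45)cc3)n2)cc1` gives 21600 nM
compound 2 `O=C(Nc1ccc(Oc2ccnc3[nH]ccc23)cc1)c1nn(-c2ccc(Br)cc2F)ccc1=O` gives 17900 nM
compound 3 `O=C(Nc1ccc(Oc2ccnc3[nH]ccc23)cc1)c1nn(-c2ccc(Cl)c(F)c2)ccc1=O` gives 3110 nM

In a functional assay on MCF7 cells (Homo sapiens) for cytotoxicity, read by MTT assay, with a stated time of 72 h (on this read-out lower numbers stand for stronger inhibition and higher numbers for weaker inhibition), compound 1 stands at the high end of the three numbers, with compound 2 separated from it by only a 1.2-fold lower number from compound 1 to compound 2 (0.08 log units; within the scatter) and compound 3 furthest away at a 6.9-fold lower number from compound 1 to compound 3 (0.84 log units; beyond the scatter). Compound 4 `O=C(Nc1ccc(Oc2ccnc3[nH]ccc23)cc1)c1nn(-c2ccc(Cl)c(C(F)(F)F)c2)ccc1=O` differs from compound 1 by 4-chloro-3-(trifluoromethyl)phenyl in place of 4-methoxyphenyl on an aromatic nitrogen. Among the compounds with values here, two measured steps bear on this exchange of 4-methoxyphenyl for a halogenated phenyl: one gave a 1.2-fold lower number from compound 1 to compound 2 (0.08 log units; within the scatter), the other 6.9-fold lower number from compound 1 to compound 3 (0.84 log units; beyond the scatter), and between the two halogenated compounds the step was a 5.8-fold lower number from compound 2 to compound 3 (0.76 log units; beyond the scatter). Compound 4 is therefore expected to show a modest step down, an 8.6-fold lower number from compound 1 to compound 4 (0.94 log units; beyond the scatter). Compound 4 is estimated at 2500 nM, within the range 800 nM to 8000 nM.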

Compound 4, half-maximal inhibitory concentration: 6270 nM
The estimate for compound 4 lay 2.5-fold (0.40 log units) below the measured number; the measured number falls inside the stated range.
By their numbers in this assay, from the lowest: compounds 3 and 4 (each within the scatter of the next); then compounds 2 and 1 (each within the scatter of the next).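

In this assay, 4-chloro-3-(trifluoromethyl)phenyl on this aromatic nitrogen gives a 3.4-fold lower number from compound 1 to compound 4 (0.54 log units; beyond the scatter) and, against 4-bromo-2-fluorophenyl, a 2.9-fold lower number from compound 2 to compound 4 (0.46 log units; beyond the scatter) as a second halogenated phenyl clearly separated from 4-methoxyphenyl. Trifluoromethyl in place of fluoro on the aromatic carbon gives a 2.0-fold higher number from compound 3 to compound 4 (0.30 log units; within the scatter) and so this assay does not tell the two groups apart here. Nothing measured here explains these differences. Going by these compounds, whether a phenyl carrying an amine or a carboxylic acid would hold this level remains open, as does the effect of replacing the phenyl with a longer alkyl chain.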